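A Trifluoromethyl Group Added to Compound 1

A few compounds are considered here, and "the series" means these few. Any claim that something is new, unique, unknown or untested is made for them only; others in the source may bear on it.

Compound 1, `CC(C#Cc1cccc(C(=O)NCCC(c2ccccc2)c2ccccc2)c1)N(O)C(N)=O`: 300 nM
Compound 2, `C[C@H](C#Cc1cccc(C(=O)NCc2ccccc2C(F)(F)F)c1)N(O)C(N)=O`: 600 nM
Compound 3, `CC(C#Cc1cccc(C(=O)NCc2ccccc2C(F)(F)F)c1)N(O)C(N)=O`: 700 nM

In an assay for inhibition of Polyunsaturated fatty acid 5-lipoxygenase (Homo sapiens), read by HPLC, with stated times of 15 min and 10 min (a higher number here means a weaker inhibitor, a lower number a stronger inhibitor), compound 1 gives 300 nM, the lowest of the three numbers, with compound 2 nearest and compound 3 furthest away. Within the data shown here, compound 2 and compound 3 share every atom and bond, and the one measured step between them, a 1.2-fold higher number from compound 2 to compound 3 (0.07 log units; within the scatter), lies within the scatter; the only thing that separates them is the fact that one of compounds 2 and 3 is drawn with a defined configuration and the other without, at the place where they differ.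

Compound 4, `CC(C#Cc1cccc(C(=O)NCCC(c2ccccc2)c2ccc(C(F)(F)F)cc2)c1)N(O)C(N)=O`, differs from compound 1 in one place: trifluoromethyl in place of hydrogen on an aromatic carbon. Among the measured compounds shown here, no measured step bears on this kind of change. For the measured compounds named here, the single step on hand concerns a drawn configuration, not a substituent, and compounds 2 and 3, although they carry a trifluoromethyl group, sit on a different amide portion, so their values against compound 1 describe no single change. With nothing to point either way, compound 4 is expected to stay close to compound 1, with a step of no change at the digits printed from compound 1 to compound 4 (within the scatter), which is no step beyond the scatter. Compound 4 is therefore estimated at 300 nM in this assay, within a range from 100 nM to 900 nM.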

Compound 4, half-maximal inhibitory concentration: 150 nM
For compound 4 the middle estimate is 2.0-fold (0.30 log units) above the measured one; the measured number falls inside the stated range.
By their numbers in this assay, from the lowest: compounds 4, 1, 2 and 3 (each within the scatter of the next, the first and the last beyond it).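

In this assay, among these compounds, trifluoromethyl in place of hydrogen on an aromatic carbon, para to a large group, gives a 2.0-fold lower number from compound 1 to compound 4 (0.30 log units; within the scatter), the first step here that concerns a substituent rather than a drawn configuration. Among the compounds shown here, compounds 2 and 3 also carry trifluoromethyl, but on a different amide portion, so only this pair isolates the change, and it shows that this place on compound 1 can take a group of four heavy atoms with a step that stays within the scatter. The only observation on hand concerns a drawn configuration in another pair of compounds and does not bear on this substituent change, so nothing here accounts for the result.

The compounds shown leave open how this same place responds to other groups, such as a chlorine atom, a methoxy group, a nitrile or a carboxylic acid, and whether trifluoromethyl on another carbon of the ring, or on both phenyl rings, would give a step beyond the scatter. They also leave open whether a defined configuration at the saturated chain carbon would change the value of compound 4 in this assay or leave it within the scatter, as it does for the pair of compounds 2 and 3.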